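This account rests on a few compounds, and the source may have more. Where it says the series, first, only, none or still open, it means among the compounds named here.

Measured compounds in an assay on CHO-K1 cells for antagonist activity at transient receptor potential cation channel subfamily V member 1 (Homo sapiens), read by FLIPR and calcium flux, with a stated time of 6 min; a higher number here means a weaker inhibitor, a lower number a stronger inhibitor:
compound 1 `Cn1ncc2c(NC(=O)NCc3cc(C(F)(F)F)nn3-c3ccc(C(F)(F)F)cc3)cccc21`: 3.9 nM
compound 2 `Cn1ncc2c(NC(=O)NCc3cc(C(C)(C)C)nn3-c3cccc(C(F)(F)F)c3)cccc21`: 0.6 nM
compound 3 `Cn1ncc2c(NC(=O)NCc3cc(C(C)(C)C)nn3-c3ccc(Cl)cc3)cccc21`: 9.5 nM

Compound 3 gives the highest number of the three in this assay; compound 1 sits somewhat lower, and compound 2 lies well below both. The step from compound 3 to compound 4, whose structure is `Cn1ncc2c(NC(=O)NCc3cc(C(C)(C)C)nn3-c3ccc(C(F)(F)F)cc3)cccc21`, is trifluoromethyl in place of chloro on an aromatic carbon. For the measured compounds named here, the one measured step that bears on this is a 16-fold higher number from compound 2 to compound 3 (1.20 log units; beyond the scatter), a large change; it is not the same change, since the trifluoromethyl there sits on a different carbon of the ring, but it shows that the aryl on the pyrazole nitrogen matters and that a 4-chlorophenyl gave the weaker compound. Going by the values given here, compound 1, which carries a 4-(trifluoromethyl)phenyl but a trifluoromethyl rather than a tert-butyl on the pyrazole, gives a lower number than compound 3, though no single step links the two. Compound 4 is therefore expected to come out lower than compound 3 by about a 4.8-fold lower number from compound 3 to compound 4 (0.68 log units; beyond the scatter). The estimate for compound 4 in this assay is 2 nM, with a range from 0.6 nM to 6 nM.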

Compound 4, inhibition constant: 12.4 nM
Estimate against measurement, compound 4: 6.2-fold (0.79 log units) below, and the stated range ends below it.
By their numbers in this assay, from the lowest: compound 2; then compound 1; then compounds 3 and 4 (each within the scatter of the next).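

In this assay the exchange of chloro for trifluoromethyl at this ring carbon gives a 1.3-fold higher number from compound 3 to compound 4 (0.12 log units; within the scatter) and so does not separate the two groups here. Moving to the other aryl on the aromatic nitrogen does far more, with a 21-fold higher number from compound 2 to compound 4 (1.32 log units; beyond the scatter) for 4-(trifluoromethyl)phenyl in place of 3-(trifluoromethyl)phenyl, and with that aryl held constant, tert-butyl in place of trifluoromethyl on an aromatic carbon gives a 3.2-fold higher number from compound 1 to compound 4 (0.50 log units; beyond the scatter). No measurement is at hand that accounts for these differences.

The compounds shown leave open whether a methoxy or a nitrile in place of the chloro would also stay within the scatter of compound 3. They also leave open whether the exchange of tert-butyl for trifluoromethyl would give a step of similar size with the 3-(trifluoromethyl)phenyl of compound 2.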